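Swapping chloro for trifluoromethyl on the benzyl ring

The source may report more compounds than this note shows. Statements on the series, on what has been measured and on what is new or still open speak of the compounds shown alone.

Measured compounds:
- compound 1 `COc1ccc([C@@H]2CC(=O)c3c(O)cc(OCc4cn(Cc5ccccc5Cl)nn4)cc3O2)cc1O`: 6140 nM
- compound 2 `COc1ccc([C@@H]2CC(=O)c3c(O)cc(OCc4cn(Cc5cccc(C(F)(F)F)c5)nn4)cc3O2)cc1O`: 19900 nM
- compound 3 `COc1ccc([C@@H]2CC(=O)c3c(O)cc(OCc4cn(CC5CC5)nn4)cc3O2)cc1O`: 11900 nM

These three compounds share one core and differ only in the group attached to the saturated chain carbon bound to an aromatic nitrogen. In a functional assay on RAW264.7 cells (Mus musculus) for inhibition, read by Griess assay, with stated times of 2 h and 24 h (a higher number here means a weaker inhibitor, a lower number a stronger inhibitor), compound 1 gives the lowest of the three numbers, so it is the best inhibitor seen so far; its step to compound 3 lies within the scatter, while its step to compound 2 lies beyond it.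

Compound 4 `COc1ccc([C@@H]2CC(=O)c3c(O)cc(OCc4cn(Cc5ccccc5C(F)(F)F)nn4)cc3O2)cc1O` differs from compound 1 by trifluoromethyl in place of chloro on an aromatic carbon, on an aromatic carbon of a six-membered aromatic ring of carbon only, ortho to a large group. The closest comparison is a 3.2-fold higher number from compound 1 to compound 2 (0.51 log units; beyond the scatter), where a 3-(trifluoromethyl)phenyl replaces the 2-chlorophenyl, changing both the group and its position; a 1.9-fold higher number from compound 1 to compound 3 (0.29 log units; within the scatter) shows that removing the ring altogether costs little. For compound 4 a small loss, a 1.5-fold higher number from compound 1 to compound 4 (0.17 log units; within the scatter), is therefore expected in this assay. Compound 4 is estimated at 9000 nM, with a range from 4500 nM to 20000 nM.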

Compound 4, half-maximal inhibitory concentration: 12500 nM
Compound 4: middle estimate off by 1.4-fold (0.14 log units), on the low side; the measured number falls inside the stated range.
By their numbers in this assay, from the lowest: compounds 1, 3, 4 and 2 (each within the scatter of the next, the first and the last beyond it).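

In this assay, for the compounds shown here, trifluoromethyl in place of chloro at the same ring place gives a 2.0-fold higher number from compound 1 to compound 4 (0.31 log units; beyond the scatter) and is the first step here that changes the group alone, so at this place chloro holds a small edge. The ring position of trifluoromethyl does not separate the compounds, since 2-(trifluoromethyl)phenyl in place of 3-(trifluoromethyl)phenyl gives a 1.6-fold lower number from compound 2 to compound 4 (0.20 log units; within the scatter) and the same group in place of cyclopropyl gives a 1.1-fold higher number from compound 3 to compound 4 (0.02 log units; within the scatter) with neither step beyond the scatter. Nothing measured here offers a reason for the edge held by chloro.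

From the compounds shown here alone, whether a fluoro, methyl or methoxy group at this ring place would match chloro remains open. So does the effect of an amine or a carboxylic acid on the benzyl ring.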